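A few compounds are considered here, and "the series" means these few. Any claim that something is new, unique, unknown or untested is made for them only; others in the source may bear on it.

Going by the values given here, compound 2 `COc1ccc(F)c(-c2ccc(Cc3ccc(N4C[C@@H](C(F)(F)F)C[C@H]4CC(=O)O)cc3)c(C)c2)c1` gives 2400 nM in a functional assay on cells for agonist activity at Free fatty acid receptor 1 (Mus musculus), read by FLIPR and calcium flux, with a stated time of 100 s (on this read-out higher numbers stand for an effect only at larger amounts of compound and lower numbers for an effect already at smaller amounts), and compound 1 `COc1ccc(F)c(-c2ccc(Cc3ccc(N4CCC[C@H]4CC(=O)O)cc3)c(C)c2)c1` gives 1900 nM; the change is a 1.3-fold higher number from compound 1 to compound 2 (0.10 log units; within the scatter), so compound 2 stands beside the only other measured compound, within the scatter. Compound 3 `COc1ccc(F)c(-c2ccc(Cc3ccc(N4C[C@H](C(F)(F)F)C[C@@H]4CC(=O)O)cc3)c(C)c2)c1` is related to compound 2 by the two compounds have the same atoms and bonds and differ only in configuration as drawn: 2 of 2 stereo elements differ (all stereocentres are inverted: mirror images); a stereocentre at a saturated ring carbon is drawn S in compound 2 and R in compound 3; a stereocentre at a saturated ring carbon is drawn S in compound 2 and R in compound 3. Among the compounds with values here, no measured step concerns an inversion of configuration; the one step, trifluoromethyl in place of hydrogen on a saturated ring carbon, gives no guide, and the direction rests on the mirror-image relation alone. For compound 3 the expected step is a 3.3-fold higher number from compound 2 to compound 3 (0.52 log units; beyond the scatter), toward a higher number. Compound 3 is estimated at 8000 nM, between 1500 nM and 40000 nM.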

Compound 3, half-maximal effective concentration: 54 nM
Estimate against measurement, compound 3: 150-fold (2.17 log units) above, and the stated range ends above it.
By their numbers in this assay, from the lowest: compound 3; then compounds 1 and 2 (each within the scatter of the next).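

In this assay the mirror-image pair separates widely, with a 44-fold lower number from compound 2 to compound 3 (1.65 log units; beyond the scatter) in the number. The trifluoromethyl group had seemed to count for little in a 1.3-fold higher number from compound 1 to compound 2 (0.10 log units; within the scatter) but that reading covers only the configuration drawn in compound 2. The large gap can be laid to configuration alone, because of this: the fact that compounds 2 and 3 differ only in the configuration as drawn.

From the compounds shown here alone, both stereocentres invert together, so which of them carries the gap remains open. Also open, going by these compounds, is whether a methyl group or a chlorine atom on that ring carbon, in the configuration of compound 3, would give a similar number.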